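Azole swaps on the sulfur-linked methylene: tetrazole step

The source may report more compounds than this note shows. Statements on the series, on what has been measured and on what is new or still open speak of the compounds shown alone.

Measured so far:
compound 1 `CCOc1ccc(-c2c(C#N)c(N)nc(SCc3ccn[nH]3)c2C#N)cc1` — 18%
compound 2 `N#Cc1c(N)nc(SCc2cccc(C(N)=O)c2)c(C#N)c1-c1ccc(OCC2CC2)cc1` — 1%
compound 3 `N#Cc1c(N)nc(SCc2ncn[nH]2)c(C#N)c1-c1ccc(OCC2CC2)cc1` — 1%

In an assay on CHO cells for displacement of a labelled ligand from adenosine receptor A3 (Homo sapiens), read by scintillation counting, with a stated time of 120 min, tested at 1 uM (on this read-out higher numbers stand for more inhibition at the one concentration tested (going by the name of the read-out) and lower numbers for less inhibition), compound 3 sits level with compound 2 at the digits shown, and these two are together the lowest of the three numbers. Among the compounds with values here, compound 1, the only member with a different ether on the aryl group and a pyrazole on the sulfur-linked methylene, stands higher by a margin beyond the scatter; no single-point step connects it to compound 3, so its values are only read side by side.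

Within the data shown here, the one step that bears on the next change is no change at the digits printed from compound 2 to compound 3 (within the scatter): exchanging a substituted phenyl for a five-membered azole on the same saturated chain carbon left the read-out where it was.

Compound 4 `N#Cc1c(N)nc(SCc2nnn[nH]2)c(C#N)c1-c1ccc(OCC2CC2)cc1` differs from compound 3 only in 1H-tetrazol-5-yl in place of 1H-1,2,4-triazol-5-yl on a saturated chain carbon bound to a sulfur. This is a smaller structural move than the step from compound 2 to compound 3, which itself produced nothing beyond the scatter, so from compound 3 to compound 4 no movement beyond the scatter is expected, a number 2 percentage points higher from compound 3 to compound 4 (within the scatter).

Compound 4 is therefore estimated at 3% in this assay, with a likely range of -8% to 15%.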

Compound 4, a percentage reported as inhibition, at one concentration (the size of the read-out at that concentration, not a potency): 1%
The estimate for compound 4 lay 2 percentage points above the measured number; the measured number falls inside the stated range.
By their numbers in this assay, from the lowest: compounds 2, 3 and 4 (each within the scatter of the next); then compound 1.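

In this assay the exchange on a saturated chain carbon bound to a sulfur gives no change at the digits printed from compound 3 to compound 4 (within the scatter) and adds a ring nitrogen, so 1H-tetrazol-5-yl and 1H-1,2,4-triazol-5-yl cannot be told apart at this position on this read-out. The comparison with the six-membered aromatic group gives no change at the digits printed from compound 2 to compound 4 (within the scatter) and now rests on two azoles rather than one, so 3-carbamoylphenyl and both azoles read alike at the single concentration tested, and with numbers this low the result ranks none of the three. No measured evidence is available to explain why these groups read alike.

Whether an amine, a carboxylic acid or a longer chain between the sulfur and the azole would lift the read-out at this position remains open, since all three groups shown here are ring groups on a single methylene. As far as these compounds go, compound 1 at 18% in this assay differs from compound 3 and compound 4 in both the ether and the azole, so it remains open which of these two places goes with its number.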